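The source may hold more compounds than are shown below. What is called first, only, known or untested is meant among the compounds shown, and "the series" means these compounds.

The series rests on three measured compounds, and in a functional assay on the whole organism (stomach) for inhibition, with Rattus norvegicus as the target, with a stated time of 4 h (a higher number here means that more compound is needed for the effect, a lower number that less compound is needed), each of them is known only as a limit. Compound 1 `C/N=C(\NC#N)NCCSCn1nc(C)ccc1=O` gives > 100 mg/kg, which is a limit of the assay. Compound 2 `CC/N=C(\NC#N)NCCSCCn1nc(-c2ccccc2)ccc1=O` gives < 100 mg/kg, also a limit. Compound 3 `C/N=C(\NC#N)NCCOCn1nc(-c2ccccc2)ccc1=O` gives < 82.3 mg/kg, again a limit rather than a number, so compound 3 stands among bounds with no measured point to set it against. Compound 4 `C/N=C(\NC#N)NCCCOCn1nc(-c2ccccc2)ccc1=O` differs from compound 3 by a group of 8 heavy atoms (4 carbon, 4 nitrogen; no ring) in place of a group of 7 heavy atoms (3 carbon, 4 nitrogen; no ring), on a saturated chain carbon, two bonds along the chain from an oxygen on a saturated carbon. For the measured compounds named here, no step between measured compounds is known, so the lengthened chain is expected to shift the dose by no more than the usual scatter, in no favoured direction. For compound 4 the expected dose is 40 mg/kg, between 10 mg/kg and 120 mg/kg, an estimated step that the limit leaves unreadable from compound 3 to compound 4.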

Compound 4, dose for half-maximal effect: < 100 mg/kg
Compound 4: a limit, no number (the forecaster's own chance of this, stated with the estimate: 60%); the middle value does not contradict the limit.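

In this assay, for the compounds shown here, compound 3 and compound 4 are each known only as a limit, and no step between them can be read. The compounds shown leave open whether the group of 8 heavy atoms, in place of the group of 7 heavy atoms, changes the dose at all.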